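The source may report more compounds than this note shows. Statements on the series, on what has been measured and on what is new or still open speak of the compounds shown alone.

Compound 2 `CCCC(=O)N1CCC(NS(=O)(=O)c2ccc(NC(=O)CC3CCCC3)c3ccccc23)CC1` gives 145 nM in an in vitro functional assay on CHO/Galpha16 cells for antagonist activity at C-C chemokine receptor type 8 (Homo sapiens), read by FLIPR (on this read-out higher numbers stand for weaker inhibition and lower numbers for stronger inhibition), the highest number of the three measured compounds; compound 1 `CCCC(=O)N1CCC(NS(=O)(=O)c2ccc(NC(=O)c3ccccc3)c3ccccc23)CC1` gives 12.5 nM and compound 3 `CCCC(=O)N1CCC(NS(=O)(=O)c2ccc(NC(=O)c3cc(C)oc3C(F)(F)F)c3ccccc23)CC1` gives 46.9 nM. Two measured steps lead away from compound 2: a 12-fold higher number from compound 1 to compound 2 (1.06 log units; beyond the scatter) and a 3.1-fold lower number from compound 2 to compound 3 (0.49 log units; beyond the scatter). Compound 4 `CCCC(=O)N1CCC(NS(=O)(=O)c2ccc(NC(=O)c3cccnc3)c3ccccc23)CC1` is compound 2 with pyridin-3-yl in place of cyclopentylmethyl on a carbonyl carbon. The entering group is a six-membered aromatic ring, as is the phenyl of compound 1. The measured step between the phenyl and the cyclopentylmethyl reads a 12-fold higher number from compound 1 to compound 2 (1.06 log units; beyond the scatter). Among the measured compounds shown here, the move from compound 2 to compound 4 is expected to resemble the reverse of that step, a large move to a lower number, although no measured compound carries a ring nitrogen, which widens the range. Compound 4 is therefore expected to give 20 nM (range 7 nM to 60 nM). This corresponds to an expected step of a 7.3-fold lower number from compound 2 to compound 4 (0.86 log units; beyond the scatter).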

Compound 4, half-maximal inhibitory concentration: 885 nM
The estimate for compound 4 lay 44-fold (1.65 log units) below the measured number, and the stated range ends below it.
By their numbers in this assay, from the lowest: compound 1; then compound 3; then compound 2; then compound 4.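

In this assay, a six-membered aromatic ring on this carbonyl carbon does not by itself give a low number: pyridin-3-yl in place of phenyl gives a 71-fold higher number from compound 1 to compound 4 (1.85 log units; beyond the scatter), a change of one ring atom to nitrogen. The pyridine also falls behind the other two groups, with a 6.1-fold higher number from compound 2 to compound 4 (0.79 log units; beyond the scatter) and a 19-fold higher number from compound 3 to compound 4 (1.28 log units; beyond the scatter), so here the non-aromatic cyclopentylmethyl outperforms an aromatic ring. No measurement on hand accounts for this loss. Open, on these data alone, is how pyridin-4-yl or pyridin-2-yl would read on this carbonyl carbon, and so whether the ring nitrogen's location matters.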